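Ring in Place of Chain on the Aromatic Nitrogen

A few compounds are considered here, and "the series" means these few. Any claim that something is new, unique, unknown or untested is made for them only; others in the source may bear on it.

Of the compounds shown here, three sharing one core have been tested in a functional assay on HepG2 cells (Homo sapiens) for antiproliferative activity, read by CCK-8 assay, with a stated time of 72 h, tested at 2 uM; on this read-out lower numbers stand for a weaker effect and higher numbers for a stronger effect at the one concentration tested. Compound 1 `CC(C)n1cnc2c(Nc3cccc(Cl)c3)nc(NCOCc3ccc(C(=O)Nc4ccccc4N)cc3)nc21` gives 1.48%, compound 2 `Nc1ccccc1NC(=O)c1ccc(COCNc2nc(Nc3ccccc3)c3ncn(C4CCCC4)c3n2)cc1` gives 37.5%, and compound 3 `CCCCn1cnc2c(Nc3cccc(Cl)c3)nc(NCOCc3ccc(C(=O)Nc4ccccc4N)cc3)nc21` gives 30.6%. For the measured compounds named here, compound 3 thus stands second highest of the three numbers: its gap to compound 2 lies within the scatter, while the single measured step, a number 29.1 percentage points higher from compound 1 to compound 3 (beyond the scatter), lies beyond it. Compound 4 `Nc1ccccc1NC(=O)c1ccc(COCNc2nc(Nc3cccc(Cl)c3)c3ncn(C4CCCC4)c3n2)cc1` differs from compound 3 in one place: cyclopentyl in place of butyl on an aromatic nitrogen. Going by the values given here, no measured step covers this exact exchange. Among the compounds with values here, the only step available, a number 29.1 percentage points higher from compound 1 to compound 3 (beyond the scatter), shows that the group on this aromatic nitrogen can shift the read-out by a modest amount. Compound 2 also carries cyclopentyl, though the rest of the molecule is not identical, and compound 2 with its 37.5% sits near compound 3. The step is therefore expected to be small, a number 7.4 percentage points higher from compound 3 to compound 4 (within the scatter), within the scatter. Compound 4 is estimated at 38%, with a range from 15% to 65%.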

Compound 4, a percentage reported as inhibition, at one concentration (the size of the read-out at that concentration, not a potency): 32.6%
For compound 4 the middle estimate is 5.4 percentage points above the measured one; measured number inside the range.
By their numbers in this assay, from the lowest: compound 1; then compounds 3, 4 and 2 (each within the scatter of the next).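

In this assay, cyclopentyl in place of butyl on the aromatic nitrogen leaves the read-out within the scatter (a number 2 percentage points higher from compound 3 to compound 4 (within the scatter)), so a ring and an open chain are not told apart at this position. Cyclopentyl in place of isopropyl gives a much larger step (a number 31.1 percentage points higher from compound 1 to compound 4 (beyond the scatter)), which leaves isopropyl as the one group apart from the others, although only these three groups are compared here. With cyclopentyl on the nitrogen, chloro in place of hydrogen on an aromatic carbon also stays within the scatter (a number 4.9 percentage points lower from compound 2 to compound 4 (within the scatter)).

Nothing available explains why isopropyl stands apart from butyl and cyclopentyl. As far as these compounds go, it remains open whether a methyl group, a cyclohexyl ring or a longer chain ending in an amine on this nitrogen would match butyl and cyclopentyl or isopropyl.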